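The source may hold more compounds than are shown below. What is called first, only, known or untested is meant among the compounds shown, and "the series" means these compounds.

Compound 1 `CSc1cc(C(=O)N2CCc3ccccc32)cc(C#N)c1O` gives 40000 nM
Compound 2 `N#Cc1cc(C(=O)N2CS(=O)(=O)c3ccccc32)cc(C2CC2)c1O` gives 59000 nM
Compound 3 `CC(C)c1cc(C(=O)N2CS(=O)(=O)c3ccccc32)cc(C#N)c1O` gives 12000 nM

In a toxicity assay on mitochondria from liver (Rattus norvegicus) for inhibition, in the presence of a further agent that is not named here (a higher number here means a weaker inhibitor, a lower number a stronger inhibitor), compound 3 has the lowest number of the three, which makes it the strongest inhibitor measured so far. Compound 4 `CCc1cc(C(=O)N2CS(=O)(=O)c3ccccc32)cc(C#N)c1O` differs from compound 3 in one place, isopropyl to ethyl (hydrogen in place of methyl on a saturated chain carbon bound to an aromatic carbon and a saturated chain carbon), that is, hydrogen in place of methyl on a saturated chain carbon bound to an aromatic carbon and a saturated chain carbon. For the measured compounds named here, no compound carrying ethyl has been measured yet. Going by the values given here, only one measured step bears on this change: a 4.9-fold lower number from compound 2 to compound 3 (0.69 log units; beyond the scatter) for isopropyl in place of cyclopropyl on an aromatic carbon. That step is modest, so a modest step is expected here too. A higher number is the likelier direction, since compound 3 gives 12000 nM and the other two compounds both lie higher, though a single step cannot settle this. In this assay the expected change is a 1.8-fold higher number from compound 3 to compound 4 (0.26 log units; within the scatter) as an estimate. For compound 4 the estimated value is 22000 nM with an expected range of 9000 nM to 55000 nM in a repeat measurement.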

Compound 4, half-maximal inhibitory concentration: 37000 nM
For compound 4 the middle estimate is 1.7-fold (0.23 log units) below the measured one; the measured number falls inside the stated range.
By their numbers in this assay, from the lowest: compound 3; then compounds 4, 1 and 2 (each within the scatter of the next).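

Going from isopropyl to ethyl, a change of a single methyl, gives a 3.1-fold higher number from compound 3 to compound 4 (0.49 log units; beyond the scatter) in this assay and so weakens the inhibition by more than the usual scatter. Ethyl and cyclopropyl on this aromatic carbon, by contrast, give a 1.6-fold lower number from compound 2 to compound 4 (0.20 log units; within the scatter) and cannot be told apart, so among these three groups only isopropyl stands apart. Nothing available here explains why this methyl matters.

The compounds shown leave open whether tert-butyl, which carries one more methyl than isopropyl, would lower the number further. They also leave open whether a longer chain such as propyl, or a chain ending in an amine, would sit with isopropyl or with ethyl in this assay.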